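The source may report more compounds than this note shows. Statements on the series, on what has been measured and on what is new or still open speak of the compounds shown alone.

Measured so far: compound 1 `CCn1cc(Nc2ncc3cnn(-c4ccc(OC)cc4)c3n2)cn1` with 133 nM; compound 2 `CCn1cc(Nc2ncc3c(C)nn(-c4ccc(OC)cc4)c3n2)cn1` with 81 nM.

In an assay on isolated protein for inhibition of eIF-2-alpha kinase GCN2 (Homo sapiens) (on this read-out lower numbers stand for stronger inhibition and higher numbers for weaker inhibition), compound 2 holds the lower of the two numbers, yet the gap a 1.6-fold lower number from compound 1 to compound 2 (0.22 log units; within the scatter) is within the scatter, so the two compounds cannot be ordered. Compound 3 `CCn1cc(Nc2ncc3c(C)nn(-c4ccc(C#N)cc4)c3n2)cn1` differs from compound 2 by cyano in place of methoxy on an aromatic carbon. Within the data shown here, no measured step touches that group: the only step, a 1.6-fold lower number from compound 1 to compound 2 (0.22 log units; within the scatter), concerns a methyl elsewhere and is itself within the scatter. The account therefore expects no change beyond the scatter, a 1.2-fold higher number from compound 2 to compound 3 (0.09 log units; within the scatter), with a wide range. Compound 3 is estimated at 100 nM, from 30 nM to 350 nM.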

Compound 3, half-maximal inhibitory concentration: 56 nM
The estimate for compound 3 lay 1.8-fold (0.25 log units) above the measured number; the measured number falls inside the stated range.
By their numbers in this assay, from the lowest: compounds 3, 2 and 1 (each within the scatter of the next, the first and the last beyond it).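

Among these compounds, the change from 4-methoxyphenyl to 4-cyanophenyl gives the only reading at this position: in this assay the step is a 1.4-fold lower number from compound 2 to compound 3 (0.16 log units; within the scatter) and so does not order the two compounds. On this core, with the methyl of compound 2 kept, cyano and methoxy on this aromatic carbon therefore cannot be told apart by this read-out. Nothing available bears on why this is so.

As far as these compounds go, whether an amine or a carboxylic acid on the same carbon, or a longer chain in place of the methoxy, would move the number beyond the scatter stays open.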